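Stereocentre inversion at the saturated ring carbon of compound 2

The compounds below may be only part of what the source reports. "The series", "measured", "known", "first", "only" and "open" are said of these compounds alone.

Of the compounds shown here, three have been read in an assay on HEK293 cells for positive allosteric modulation of metabotropic glutamate receptor 5 (Homo sapiens), read by FLIPR; a lower number here means that less compound is needed, a higher number that more compound is needed for the effect. Compound 1 `O=C([C@H]1CC2CCC1C2)N1CC(c2nc(-c3ccccc3)no2)C1` gives 120 nM. Compound 2 `O=C([C@H]1CC2CCC1C2)N1CC(c2nc(-c3cccc(F)c3)no2)C1`, carrying fluoro in place of hydrogen on an aromatic carbon, gives 72 nM; compound 3 `O=C([C@H]1CC2CCC1C2)N1CC(c2nc(-c3cccc(Cl)c3)no2)C1`, with chloro at the same aromatic carbon, gives 74 nM. The steps that connect them are all small: a 1.7-fold lower number from compound 1 to compound 2 (0.22 log units; within the scatter), a 1.6-fold lower number from compound 1 to compound 3 (0.21 log units; within the scatter), and a 1.0-fold higher number from compound 2 to compound 3 (0.01 log units; within the scatter). Compound 2 therefore stands on a number that cannot be separated from those of compound 1 or compound 3 by this assay.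

Compound 4 `O=C([C@@H]1CC2CCC1C2)N1CC(c2nc(-c3cccc(F)c3)no2)C1` is the next candidate. Its relation to compound 2 is purely stereochemical: the two compounds have the same atoms and bonds; at least one stereo element is drawn with a configuration in one of them and without one in the other: 1 of 3 stereo elements differ; a stereocentre at a saturated ring carbon is drawn S in compound 2 and R in compound 4. For the measured compounds named here, no measured step bears on this change; every step recorded so far concerns the substituent on the aromatic ring, and each of them stayed within the scatter. There is thus no series-internal basis for predicting the size or direction of the move in this assay, and the expectation must be wide.

Pending measurement, compound 4 is estimated at 250 nM, with a range of 60 nM to 3000 nM, an expected step of a 3.5-fold higher number from compound 2 to compound 4 (0.54 log units; beyond the scatter).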

Compound 4, half-maximal effective concentration: 100 nM
Compound 4: middle estimate off by 2.5-fold (0.40 log units), on the high side; the range from low to high includes it.
By their numbers in this assay, from the lowest: compounds 2, 3, 4 and 1 (each within the scatter of the next).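

In this assay, for the compounds shown here, inverting the stereocentre at the saturated ring carbon gives a 1.4-fold higher number from compound 2 to compound 4 (0.14 log units; within the scatter), and this is the only step that touches anything other than the substituent on the aromatic ring. With the fluoro substituent in place, the S and R drawings at this carbon therefore cannot be told apart by this read-out, so this pair shows no dependence on the configuration at that carbon. The reading rests on this single pair and carries one qualification: the fact that one of compounds 2 and 4 is drawn with a defined configuration and the other without, at the place where they differ.

From the compounds shown here alone, whether the same holds with hydrogen or chloro on the aromatic ring stays open, since compound 1 and compound 3 appear in one configuration only. Also open, going by these compounds, is how far the saturated ring itself tolerates change, for example a hydroxyl group or an amine on that ring, or a simple cyclohexyl ring in its place on the carbonyl.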